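Nitro-for-bromo swap in a thiourea benzothiazole pair

This account rests on a few compounds, and the source may have more. Where it says the series, first, only, none or still open, it means among the compounds named here.

Measured so far:
compound 1, `O=C(NC(=S)Nc1nc2cc([N+](=O)[O-])ccc2s1)N1CCOCC1`: 54800 nM
compound 2, `O=C(NC(=S)Nc1nc2cc(Br)ccc2s1)c1ccc([N+](=O)[O-])cc1`: 56500 nM

In a functional assay on HeLa cells (Homo sapiens) for cytotoxicity, read by MTT assay, with a stated time of 24 h (on this read-out lower numbers stand for stronger inhibition and higher numbers for weaker inhibition), compound 2 gives 56500 nM and compound 1 gives 54800 nM; the two values lie within the usual scatter of each other, so compound 2 stands alongside compound 1 with no separation. Compound 3, `O=C(NC(=S)Nc1nc2cc([N+](=O)[O-])ccc2s1)c1ccc([N+](=O)[O-])cc1`, differs from compound 2 by nitro in place of bromo on an aromatic carbon. Both measured compounds already carry a nitro group and sit at much the same value, so no step beyond the scatter is expected in this assay in either direction. The expected step is a 1.0-fold lower number from compound 2 to compound 3 (0.01 log units; within the scatter). Compound 3 is estimated at 55000 nM, in a range from 25000 nM to 120000 nM.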

Compound 3, half-maximal inhibitory concentration: 68500 nM
The estimate for compound 3 lay 1.2-fold (0.10 log units) below the measured number, and the stated range covers the measured number.
By their numbers in this assay, from the lowest: compounds 1, 2 and 3 (each within the scatter of the next).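

In this assay, nitro in place of bromo on an aromatic carbon gives a 1.2-fold higher number from compound 2 to compound 3 (0.08 log units; within the scatter) and so leaves the two groups without separation at this position. 4-Nitrophenyl in place of morpholin-4-yl on a carbonyl carbon gives a 1.3-fold higher number from compound 1 to compound 3 (0.10 log units; within the scatter) and shows no separation at that site either, with nitro held on the core. No measured evidence bears on the reason for either result.

Going by these compounds, whether an amine or a carboxylic acid at the bromo and nitro position would stay within the scatter remains open. So does whether any change to the shared core separates compounds in this assay at all.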